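Fluoro for Hydrogen on the Pyridin-2-yl Ring

The source may report more compounds than this note shows. Statements on the series, on what has been measured and on what is new or still open speak of the compounds shown alone.

Of the compounds shown here, two from this series have been measured in a physicochemical assay for lipophilicity, read by LC-MS, in phosphate buffer, measured as octanol-water partition, with a stated time of 30 min, at pH 7.4, tested at 200 mM; a higher number here means a more lipophilic compound, a lower number a more polar compound. Compound 1, `Cc1cc(C)cc(Oc2ccc3nc(COc4cccc(C(=O)O)c4)n(C)c3n2)c1`, gives 2.3 in this assay. Compound 2, `Cn1c(COc2cccc(C(=O)O)c2)nc2ccc(Oc3ccccn3)cc21`, gives 0.4 in this assay and so stands lowest of the two numbers; its distance from compound 1 lies beyond the scatter of repeated measurements.

Compound 3, `Cn1c(COc2cccc(C(=O)O)c2)nc2ccc(Oc3ncccc3F)cc21`, has not yet been measured. It differs from compound 2 in one place: fluoro in place of hydrogen on an aromatic carbon. Cut one bond further out, the same difference reads pyridin-2-yl to 3-fluoropyridin-2-yl. Going by the values given here, no pair of measured compounds in this set differs by exactly this change, so the size of the step cannot be read from the data and has to be estimated. In this assay the step from compound 2 is expected to be small and upward, a number 0.20 log units higher from compound 2 to compound 3 (within the scatter), of about the same size as the usual scatter. Compound 3 is accordingly expected to give 0.6 in this assay, with a range from 0.2 to 1.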

Compound 3, distribution coefficient: 0.6
For compound 3 middle estimate and measured number coincide at the digits printed; measured number inside the range.
By their numbers in this assay, from the lowest: compounds 2 and 3 (each within the scatter of the next); then compound 1.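

In this assay, this pair gives the series its first step that can be read, since compound 1 and compound 2 differ in more than one place and offered none. The step is a number 0.20 log units higher from compound 2 to compound 3 (within the scatter), so fluoro in place of hydrogen at this site, on an aromatic carbon ortho to a large group and two atoms from the ring nitrogen, does not move the number beyond what repeated measurements would show. Going by these compounds alone, this single pair is the only reading of the change from pyridin-2-yl to 3-fluoropyridin-2-yl, and nothing measured alongside it bears on why the step has this size. Still open, as far as these compounds go, is whether a chloro, methoxy or amine group on the same aromatic carbon would stay as close to compound 2 as fluoro does, or would instead produce a step beyond the scatter. Also open, from the compounds shown here alone, is whether fluoro on the other carbons of this ring, or the same exchange on a different core, would give a step of similar size.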